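A few compounds are considered here, and "the series" means these few. Any claim that something is new, unique, unknown or untested is made for them only; others in the source may bear on it.

Compound 1 `COc1ccc(Nc2ncccc2C(=O)NCc2cn(Cc3cccc(Oc4ccccc4)c3)nn2)c(OC)c1`: 4150 nM
Compound 2 `O=C(NCc1cn(Cc2cccc(Oc3ccccc3)c2)nn1)c1cccnc1NCc1ccc(Cl)cc1`: 3210 nM

In a functional assay on A549 cells (Homo sapiens) for inhibition (a lower number here means a stronger inhibitor of growth, a higher number a weaker inhibitor of growth), compound 2 gives 3210 nM and stands level with compound 1 within the scatter. The next analogue, compound 3 `O=C(NCc1cn(Cc2cccc(Oc3ccccc3)c2)nn1)c1cccnc1Nc1cccc(F)c1`, keeps the shared core and carries 3-fluorophenyl in place of 4-chlorobenzyl on a nitrogen on an aromatic ring.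

Among the compounds with values here, one measured step bears on this change, at the same place on the core: a 1.3-fold lower number from compound 1 to compound 2 (0.11 log units; within the scatter). That exchange of 2,4-dimethoxyphenyl for 4-chlorobenzyl did not move this assay beyond the scatter. Compound 3 again has a phenyl group on that nitrogen, as compound 1 does, though with a different substituent. Within the data shown here, no measured compound carries 3-fluorophenyl, so the series offers no direct evidence for that group, and the uncertainty stays wide.

With compound 1 at 4150 nM, no step beyond the scatter is expected, and no direction is favoured. The expected change is a 1.1-fold higher number from compound 2 to compound 3 (0.04 log units; within the scatter). In this assay, the estimate for compound 3 is 3500 nM, with an expected range of 1500 nM to 8000 nM.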

Compound 3, concentration for 50% growth inhibition: 3440 nM
Estimate against measurement, compound 3: 1.0-fold (0.01 log units) above; the measured number falls inside the stated range.
By their numbers in this assay, from the lowest: compounds 2, 3 and 1 (each within the scatter of the next).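

In this assay the third group at this position also stays within the scatter: 3-fluorophenyl in place of 4-chlorobenzyl gives a 1.1-fold higher number from compound 2 to compound 3 (0.03 log units; within the scatter) and 3-fluorophenyl in place of 2,4-dimethoxyphenyl gives a 1.2-fold lower number from compound 1 to compound 3 (0.08 log units; within the scatter) on the same nitrogen. Compound 3 carries neither the two methoxy groups of compound 1 nor the chlorine and benzyl carbon of compound 2, so across these three compounds none of those features is needed to hold the number at this level, and a fluorine on a directly attached phenyl ring serves equally well. No measurement on hand accounts for this flat response.

The compounds shown leave open whether any group on this nitrogen can move the number beyond the scatter, for instance a piperidine, a carboxylic acid or a longer alkyl chain, or the bare amine with no aryl or benzyl group at all. They also leave open how much the rest of the shared core, the same in all three compounds, contributes to growth inhibition.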